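A Bulkier Group on the Sulfonyl Ring

The source may hold more compounds than are shown below. What is called first, only, known or untested is meant among the compounds shown, and "the series" means these compounds.

Compound 1 `Cc1ccc(S(=O)(=O)/N=C(/CCNC2=CC(=O)c3ccccc3C2=O)Nc2ccc(Cl)cc2)cc1` and compound 2 `COc1ccc(N/C(CCNC2=CC(=O)c3ccccc3C2=O)=N\S(=O)(=O)c2ccc(C)cc2)cc1OC` share a core and differ only in the group on an amine nitrogen. In a functional assay on A549 cells (Homo sapiens) for cytotoxicity, read by MTT assay, with a stated time of 48 h (a lower number here means a stronger inhibitor, a higher number a weaker inhibitor), compound 1 gives 29900 nM, and compound 2 gives 20500 nM. Going by the values given here, the single measured step, a 1.5-fold lower number from compound 1 to compound 2 (0.16 log units; within the scatter), lies within the scatter, so compound 2 carries the smaller of the two numbers without this meaning a real difference between them. Compound 3 `COc1ccc(N/C(CCNC2=CC(=O)c3ccccc3C2=O)=N\S(=O)(=O)c2ccc(C(C)(C)C)cc2)cc1OC` is compound 2 with tert-butyl in place of methyl on an aromatic carbon. Among the compounds with values here, no measured step touches this part of the molecule; the one known step changed the group on the amine nitrogen and stayed within the scatter. Nothing here points to a change beyond the scatter in this assay, so the expected step of a 1.0-fold lower number from compound 2 to compound 3 (0.01 log units; within the scatter) is small. Compound 3 is therefore estimated at 20000 nM in this assay, with a range from 7000 nM to 55000 nM.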

Compound 3, half-maximal inhibitory concentration: 16200 nM
Beside the measured number, compound 3's estimate is 1.2-fold (0.09 log units) above it, and the stated range covers the measured number.
By their numbers in this assay, from the lowest: compounds 3, 2 and 1 (each within the scatter of the next).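

Going by these compounds alone, this is the first measured step at this aromatic carbon, and in this assay replacing methyl with tert-butyl gives a 1.3-fold lower number from compound 2 to compound 3 (0.10 log units; within the scatter). Moving from 1 heavy atom to 4 at this place, on the 4-methylphenyl group of compound 2, therefore leaves no difference that can be read in these cells. The data offer no measurement that could explain this result.

Methyl and tert-butyl are the only groups shown at this carbon, and both contain only carbon and hydrogen, so it remains open whether an amine or a carboxylic acid there would move the number beyond the scatter. No step shown so far lies beyond the scatter, so it is also unknown which part of the molecule, if any, governs the number in this assay.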